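Carboxy to Hydroxymethyl: A Step from Compound 1

The compounds below may be only part of what the source reports. "The series", "measured", "known", "first", "only" and "open" are said of these compounds alone.

Measured in a functional assay on CAL1 cells for inhibition of chemerin-like receptor 1 (Homo sapiens), with a stated time of 45 min; a higher number here means a weaker inhibitor, a lower number a stronger inhibitor:
compound 1, `CCCCN(c1nc2c(C(=O)O)cccc2o1)[C@H](C)c1ccc(-c2ccccc2-c2nnn[nH]2)cc1`, gives 17 nM
compound 2, `CCCCN(c1nc2c(C(=O)O)cccc2o1)[C@H](C)c1ccc(-c2cc(Cl)ccc2-c2nc(=O)o[nH]2)cc1`, gives 1.2 nM

Of the two measured compounds, compound 1 has the higher number, and the gap to compound 2 lies beyond the usual scatter, so compound 2 is the stronger inhibitor in this assay. The two differ in more than one place, so nothing about any single change can be read from that pair.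

Compound 3, `CCCCN(c1nc2c(CO)cccc2o1)[C@H](C)c1ccc(-c2ccccc2-c2nnn[nH]2)cc1`, is not yet measured. It differs from compound 1 in one place only: hydroxymethyl in place of carboxy on an aromatic carbon of the shared core. Going by the values given here, no measured pair shows this change, so its effect in this assay is unknown here. The expectation is that compound 3 loses some potency against compound 1, a step of a 4.7-fold higher number from compound 1 to compound 3 (0.67 log units; beyond the scatter) in this assay, with the uncertainty wide enough that an outcome within the scatter cannot be ruled out. Compound 3 is accordingly estimated at 80 nM in this assay, expected to fall between 20 nM and 400 nM.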

Compound 3, half-maximal inhibitory concentration: 24 nM
Estimate against measurement, compound 3: 3.3-fold (0.52 log units) above, and the stated range covers the measured number.
By their numbers in this assay, from the lowest: compound 2; then compounds 1 and 3 (each within the scatter of the next).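

In this assay, going by these compounds alone, hydroxymethyl in place of carboxy on an aromatic carbon of the shared core gives a 1.4-fold higher number from compound 1 to compound 3 (0.15 log units; within the scatter), the first reading of a change at this position alone, and the two compounds cannot be told apart. In the setting of compound 1, then, the carboxy group is not needed at this position to keep inhibition at this level, and hydroxymethyl, with one heavy atom fewer and no double bond outside aromatic rings, serves as well in this assay. Nothing available gives a reason for this result.

The compounds shown leave open whether the same change would hold in compound 2, which differs from compound 1 in more than one place and so offers no reading of this step. Within the data shown here, they also leave open how far the position tolerates other groups, such as an aminomethyl group, a primary amide, a methyl group or a longer hydroxyethyl chain, since the single step here covers only hydroxymethyl.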